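The source may report more compounds than this note shows. Statements on the series, on what has been measured and on what is new or still open speak of the compounds shown alone.

Working notes on the sulfonamide series. Compound 1 `Cc1ccc(S(=O)(=O)N(C)c2ccc3[nH]c(-c4n[nH]c5ccccc45)cc3n2)cc1` and compound 2 `COc1ccc(S(=O)(=O)N(C)c2ccc3[nH]c(-c4n[nH]c5ccccc45)cc3n2)c(OC)c1` share a core and differ only in the aryl group on the sulfonyl sulfur. In a functional assay on KB cells (Homo sapiens) for antiproliferative activity, read by MTT assay, with a stated time of 72 h (on this read-out lower numbers stand for stronger inhibition and higher numbers for weaker inhibition), compound 1 gives 9500 nM, and compound 2 gives 10200 nM. Among the measured compounds shown here, the step of a 1.1-fold higher number from compound 1 to compound 2 (0.03 log units; within the scatter) is the only measured step so far, so compound 2 stands alongside compound 1, the two numbers within the scatter of each other and no ordering between them claimed.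

Compound 3 `CN(c1ccc2[nH]c(-c3n[nH]c4ccccc34)cc2n1)S(=O)(=O)c1cccc([N+](=O)[O-])c1` is the next variation at the same place: 3-nitrophenyl in place of 2,4-dimethoxyphenyl on a sulfonyl sulfur. For the measured compounds named here, the one measured step that bears on it, an exchange of the aryl group on the sulfonyl sulfur, was a 1.1-fold higher number from compound 1 to compound 2 (0.03 log units; within the scatter), that is, no change beyond the scatter. Going by the values given here, with only this single comparison, and no information on the nitro group elsewhere, the expectation for this assay is again no step beyond the scatter, in either direction. For compound 3 the expected step is a 1.1-fold lower number from compound 2 to compound 3 (0.03 log units; within the scatter). Compound 3 is therefore estimated at 9500 nM, with a range from 4000 nM to 23000 nM.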

Compound 3, half-maximal inhibitory concentration: 5870 nM
Beside the measured number, compound 3's estimate is 1.6-fold (0.21 log units) above it, within the range that was stated.
By their numbers in this assay, from the lowest: compounds 3, 1 and 2 (each within the scatter of the next).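

In this assay, 3-nitrophenyl on a sulfonyl sulfur gives a 1.7-fold lower number from compound 2 to compound 3 (0.24 log units; within the scatter), and the same group set against 4-methylphenyl gives a 1.6-fold lower number from compound 1 to compound 3 (0.21 log units; within the scatter). A third aryl group, now carrying a nitro group where the earlier ones carry methyl or methoxy groups, thus leaves all three compounds within the scatter of one another, and no ordering among these aryl groups can be drawn at this position. Nothing is available that bears on these steps.

Going by these compounds, it remains open whether any group at this place gives a step beyond the scatter, for instance an aryl ring bearing an amine or a carboxylic acid, or a longer alkyl chain in place of the aryl ring on the sulfonyl sulfur. All the variation shown sits at this one place, so the compounds shown also leave open how far a change elsewhere on the shared core would move the number in this assay of KB cell growth, this assay.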